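Oleyl alpha-keto oxazole: dropping the fused pyridine

A few compounds are considered here, and "the series" means these few. Any claim that something is new, unique, unknown or untested is made for them only; others in the source may bear on it.

Compound 1 `CCCCCCCC/C=C\CCCCCCC(=O)c1nc2cnccc2o1` carries an unsaturated chain on a ketone joined to a bicyclic core. In an assay on isolated protein for inhibition of Fatty-acid amide hydrolase 1 (Homo sapiens) (on this read-out lower numbers stand for stronger inhibition and higher numbers for weaker inhibition), compound 1 gives 7.2 nM, the second highest of the three numbers in hand. Compound 2 `O=C(CCCCc1ccccc1)c1nc2ncccc2o1`, with a shorter chain bearing a phenyl ring on an isomeric bicyclic core, gives 0.3 nM in this assay, the lowest of the three. Compound 3 `CCCCCC(=O)C(F)(F)F`, a simple trifluoromethyl ketone, gives 28900 nM in this assay, far above the other two. Compound 1 thus sits closer to compound 2 than to compound 3, yet well apart from both.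

The step to compound 4 `CCCCCCCC/C=C\CCCCCCC(=O)c1ncco1` keeps the chain and the carbonyl and alters only the heterocycle: a group of 5 heavy atoms (3 carbon, 1 nitrogen, 1 oxygen; one five-membered aromatic ring with 2 hetero atoms) in place of a group of 9 heavy atoms (6 carbon, 2 nitrogen, 1 oxygen; one five-membered aromatic ring with 2 hetero atoms, one six-membered aromatic ring with 1 hetero atom), on a carbonyl carbon. For the measured compounds named here, no measured pair in this set shows exactly this change. The three numbers at hand nevertheless suggest that the heterocyclic ketone is the feature separating compound 1 and compound 2 from compound 3, and the simpler ring in compound 4 leaves less of that feature behind. Compound 4 is therefore expected to move to a higher number in this assay, a step of a 42-fold higher number from compound 1 to compound 4 (1.62 log units; beyond the scatter) beyond the scatter, so that compound 4 is estimated at 300 nM, within a range from 60 nM to 1500 nM.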

Compound 4, inhibition constant: 17 nM
The estimate for compound 4 lay 18-fold (1.25 log units) above the measured number; measured number outside the range, below it.
By their numbers in this assay, from the lowest: compound 2; then compound 1; then compound 4; then compound 3.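

In this assay, putting 1,3-oxazol-2-yl in place of the larger two-ring group on the carbonyl carbon, with the unsaturated chain held constant, gives a 2.4-fold higher number from compound 1 to compound 4 (0.37 log units; beyond the scatter), a modest step. For the compounds shown here, this is the first pair that reads this position on its own, and it shows that the six-membered aromatic ring is not required for inhibition in the nanomolar range: compound 4 still gives 17 nM with the five-membered aromatic ring alone. The six-membered ring does have a measurable effect on the number, but only a modest one, and the change leaves compound 4 much closer to compound 1 than the earlier numbers alone could have indicated. Nothing at hand explains why the step is this small.

Open, on these data alone, is what a group carried on the 1,3-oxazol-2-yl ring itself, such as a carboxylic acid or a methyl ester, would do to the number. Also open is whether this step keeps its size on a shorter chain or on a chain ending in a phenyl ring, as no pair shown changes the chain alone.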